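A few compounds are considered here, and "the series" means these few. Any claim that something is new, unique, unknown or untested is made for them only; others in the source may bear on it.

Compound 1 `Cn1c(-c2ccccc2)cnc1NC(=O)c1cccc(Cl)c1` was tested in a toxicity assay on THP-1 cells (Homo sapiens) for inhibition; on this read-out higher numbers stand for lower toxicity in this test and lower numbers for higher toxicity in this test. For compound 1 the result is only a limit of the test, > 50000 nM, as the evidence shows in the limit of > 50000 nM in this assay, at which 1 of the 2 values shown sits. A second compound, compound 2 `Cc1ccc(C(=O)Nc2ncc(-c3ccccc3)o2)cc1`, gives 26000 nM in this assay. Compound 3 `Cc1ccc(C(=O)Nc2ncc(-c3ccccc3)n2C)cc1` has not yet been measured; it differs from compound 1 by 4-methylphenyl in place of 3-chlorophenyl on a carbonyl carbon. Within the data shown here, no measured pair shows this change on its own, so the step expected is an at least 1.2-fold lower number from compound 1 to compound 3 (0.09 log units; that floor lies within the scatter), which stays inside the usual scatter. Compound 3 is therefore expected to show about 40000 nM, with a likely range from 15000 nM to 100000 nM.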

Compound 3, half-maximal cytotoxic concentration: > 50000 nM
Compound 3 gave a limit, no number; the forecaster's own chance of this, stated with the estimate: 55%; middle value at least 1.2-fold (0.09 log units) away from the limit.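

Compound 1 and compound 3 both end at a limit of the test in this assay, not at a number, so no step between them can be read: the limit of > 50000 nM in this assay, at which 2 of the 3 values shown sit.

From the compounds shown here alone, whether 4-methylphenyl in place of 3-chlorophenyl on a carbonyl carbon changes the result in this assay at all stays open.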